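The source may report more compounds than this note shows. Statements on the series, on what has been measured and on what is new or still open speak of the compounds shown alone.

Measured compounds:
compound 1 `CCCCCCCCc1ccc(OCC(=O)Cn2nnnc2-c2ccccc2Cl)cc1` gives 4600 nM in an assay on microsomes from brain for inhibition of Fatty-acid amide hydrolase 1 (Rattus norvegicus), read by fluorescence and HPLC, with a stated time of 60 min; a higher number here means a weaker inhibitor, a lower number a stronger inhibitor;
compound 2 `CCCCCCCCc1ccc(OCC(=O)Cn2nnnc2-c2ccncc2)cc1` gives 190 nM;
compound 3 `CCCCCCCCc1ccc(OCC(=O)Cn2nnnc2Cc2ccccc2)cc1` gives 320 nM.

Compound 3 stands second highest of the three numbers: its nearest neighbour is compound 2, at a 1.7-fold higher number from compound 2 to compound 3 (0.23 log units; within the scatter), and its furthest is compound 1, at a 14-fold lower number from compound 1 to compound 3 (1.16 log units; beyond the scatter). Compound 4 `CCCCCCCCc1ccc(OCC(=O)Cn2nnnc2-c2ccc(C(=O)O)cc2)cc1` has not yet been measured. It differs from compound 3 by 4-carboxyphenyl in place of benzyl on an aromatic carbon.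

Going by the values given here, no measured step exchanges a benzyl for a 4-carboxyphenyl, so the guidance is indirect. The steps of a 24-fold lower number from compound 1 to compound 2 (1.38 log units; beyond the scatter) and a 14-fold lower number from compound 1 to compound 3 (1.16 log units; beyond the scatter) show that changing the group on this ring carbon can move the number a great deal, while a 1.7-fold higher number from compound 2 to compound 3 (0.23 log units; within the scatter) shows that a directly attached six-membered aromatic ring and a benzyl give numbers within the scatter of each other. As far as these compounds go, the carboxylic acid is untested here.

Compound 4 is therefore expected to give about 450 nM, between 90 nM and 2500 nM. Among the compounds with values here, the step of a 1.4-fold higher number from compound 3 to compound 4 (0.15 log units; within the scatter) is expected to be small, in either direction, but with wide uncertainty because no measured step contains the carboxylic acid.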

Compound 4, half-maximal inhibitory concentration: 3400 nM
Beside the measured number, compound 4's estimate is 7.6-fold (0.88 log units) below it; measured number outside the range, above it.
By their numbers in this assay, from the lowest: compounds 2 and 3 (each within the scatter of the next); then compounds 4 and 1 (each within the scatter of the next).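

At this ring carbon, between two ring nitrogen atoms, a directly attached six-membered aromatic ring does not by itself secure a low number in this assay: the change to 4-carboxyphenyl gives an 11-fold higher number from compound 3 to compound 4 (1.03 log units; beyond the scatter) and an 18-fold higher number from compound 2 to compound 4 (1.25 log units; beyond the scatter). The two substituted phenyl groups stand level, with a 1.4-fold lower number from compound 1 to compound 4 (0.13 log units; within the scatter), so among these four compounds the 4-carboxyphenyl and the 2-chlorophenyl sit together, apart from the pyridin-4-yl and the benzyl. Nothing available explains this separation.

As far as these compounds go, it remains open whether the carboxylic acid itself accounts for the high number of compound 4 or whether any substituted phenyl ring here would do the same. A plain phenyl, a 4-methoxycarbonylphenyl or a 4-carboxybenzyl group at this carbon would separate these readings.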